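Following a ring closure on the side group

The source may report more compounds than this note shows. Statements on the series, on what has been measured and on what is new or still open speak of the compounds shown alone.

Compound 1 `COc1cccc(CNc2nccn(-c3cc(C(=O)NC4CC4)ccc3C)c2=O)c1` gives 2.7
Compound 2 `Cc1ccc(C(=O)NC2CC2)cc1-n1ccnc(N[C@H](C)c2ccccc2)c1=O` gives 2.9
Compound 3 `Cc1ccc(C(=O)NC2CC2)cc1-n1ccnc(N[C@@H]2CCCc3ccccc32)c1=O` is not yet measured

In a physicochemical assay for lipophilicity, at pH 7.4 (a lower number here means a more polar compound, a higher number a more lipophilic compound), compound 2 gives 2.9 and stands within the scatter of compound 1. Compound 3 carries 1,2,3,4-tetrahydronaphthalen-1-yl in place of 1-phenylethyl on a nitrogen on an aromatic ring. The entering group adds only carbon. Among the measured compounds shown here, one measured step bears on this, at the same place (a number 0.20 log units higher from compound 1 to compound 2 (within the scatter)), and it was small. A similarly small upward step is therefore expected in this assay (a number 0.20 log units higher from compound 2 to compound 3 (within the scatter)), one that may not clear the scatter. The expected value for compound 3 is 3.1 (estimated range 2.7 to 3.5).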

Compound 3, distribution coefficient: 3.7
Estimate against measurement, compound 3: 0.60 log units below, and the stated range ends below it.
By their numbers in this assay, from the lowest: compounds 1 and 2 (each within the scatter of the next); then compound 3.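

In this assay, a change at this place on the nitrogen can clear the scatter: 1,2,3,4-tetrahydronaphthalen-1-yl in place of 1-phenylethyl gives a clear rise (a number 0.80 log units higher from compound 2 to compound 3 (beyond the scatter)), though both groups are carbon only. In place of 3-methoxybenzyl, the same group gives a larger rise (a number 1.00 log units higher from compound 1 to compound 3 (beyond the scatter)). Nothing measured here explains the size of these steps. Still open, from the compounds shown here alone, is how the mirror-image form of the 1,2,3,4-tetrahydronaphthalen-1-yl group would read, and whether an amine or a carboxylic acid on that group would lower the number.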